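Chlorophenyl ureas in the whole-organism assay: a second chloro

The source may hold more compounds than are shown below. What is called first, only, known or untested is meant among the compounds shown, and "the series" means these compounds.

Compound 1 `C[C@H](NC(=O)Nc1ccccc1Cl)c1ccccc1` and compound 3 `C[C@H](NC(=O)Nc1ccc(Cl)cc1Cl)c1ccccc1` differ in one place: chloro in place of hydrogen on an aromatic carbon. Compound 2 `C[C@@H](NC(=O)Nc1cccc(Cl)c1)c1ccccc1` has the same atoms as compound 1 joined differently; the difference between the two cores is not broken down here. In an ADME assay on the whole organism with Oryza sativa as the target, tested at 0.1 uM (a lower number here means a stronger effect, a higher number a weaker effect of the compound at the concentration tested), compound 1 gives 99%, compound 3 gives 100% and compound 2 gives 97%. Among the compounds with values here, the step of a number 1 percentage points higher from compound 1 to compound 3 (within the scatter) is the only measured instance of this change. Compound 4 `C[C@@H](NC(=O)Nc1cc(Cl)ccc1Cl)c1ccccc1` is not yet measured; it differs from compound 2 by chloro in place of hydrogen on an aromatic carbon, the same kind of change, but the entering chloro sits ortho to a large group and para to a chloro group rather than meta to a chloro group and para to a large group. Given the step of a number 1 percentage points higher from compound 1 to compound 3 (within the scatter) and all three values near the top of the scale, the step of a number 2 percentage points higher from compound 2 to compound 4 (within the scatter) is expected to stay within the scatter. Compound 4 is estimated at 99%, between 94% and 100%.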

Compound 4, a percentage reported as activity, at one concentration (the size of the read-out at that concentration, not a potency): 99%
Estimate against measurement, compound 4: no gap at the digits printed; the measured number falls inside the stated range.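

In this assay the chloro in place of hydrogen on an aromatic carbon gives a number 2 percentage points higher from compound 2 to compound 4 (within the scatter) and, set beside the earlier instance, shows no distinguishable difference between the two cores: the same change on two cores in this assay, a number 1 percentage points higher (within the scatter) from compound 1 to compound 3 and a number 2 percentage points higher (within the scatter) from compound 2 to compound 4, 1 percentage points apart, within the scatter of two such steps. All four values lie near the top of the scale, so the agreement is between two steps that show no measurable effect of the chloro, and it does not show that a step of real size would carry from one core to the other. The entering chloro also sits in a different place on each core, and two instances set no rule for the series.

Going by these compounds, it remains open whether a group other than chloro, such as an amine or a carboxylic acid, would move the number beyond the scatter on either core.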